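The source may hold more compounds than are shown below. What is called first, only, known or untested is meant among the compounds shown, and "the series" means these compounds.

Of the compounds shown here, two have so far been tested in a functional assay on MCF7 cells (Homo sapiens) for inhibition, read by MTT assay, with a stated time of 4 days; a higher number here means a weaker inhibitor, a lower number a stronger inhibitor. Compound 1 `CCOC(=O)NC(c1ccccc1)c1ccc(Cl)cc1` is reported only at the limit of > 100000 nM in this assay, at which 1 of the 2 values shown sits, so its value of > 100000 nM is a limit and not a number. Among the compounds with values here, compound 2 `COc1cc(NC(C)CCCNC(=O)NNC(=O)Nc2ccc(Cl)c(C(F)(F)F)c2)c2ncccc2c1` gives 2000 nM in this assay, the only actual number in this set. Compound 3 `COc1cc(NC(C)CCCNC(=O)NNC(=O)NC(CO)(CO)CO)c2ncccc2c1` differs from compound 2 in one place: 2-hydroxy-1,1-bis(hydroxymethyl)ethyl in place of 4-chloro-3-(trifluoromethyl)phenyl on an amide-type nitrogen. Within the data shown here, no measured step of this kind exists here, so the expectation rests on the structural change alone. Compound 3 is expected to be weaker than compound 2, by an estimated 10-fold higher number from compound 2 to compound 3 (1.00 log units; beyond the scatter). The estimate for compound 3 in this assay is 20000 nM, expected to fall between 5000 nM and 100000 nM.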

Compound 3, half-maximal inhibitory concentration: 28000 nM
Compound 3: middle estimate off by 1.4-fold (0.15 log units), on the low side, and the stated range covers the measured number.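

In this assay, the group on this amide-type nitrogen matters: 2-hydroxy-1,1-bis(hydroxymethyl)ethyl in place of 4-chloro-3-(trifluoromethyl)phenyl gives a 14-fold higher number from compound 2 to compound 3 (1.15 log units; beyond the scatter). Even with no ring at this place, compound 3 still gives an actual number. Compound 1 alone is reported as a limit and not a number: the limit of > 100000 nM in this assay, at which 1 of the 3 values shown sits.

This single step cannot separate the loss of the aromatic ring from the arrival of the hydroxyl groups. An unsubstituted phenyl or a tert-butyl group on this nitrogen would bear on that question.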